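The compounds below may be only part of what the source reports. "The series", "measured", "known", "first", "only" and "open" are said of these compounds alone.

Measured so far in a functional assay on MCF7 cells (Homo sapiens), tested at 2.5 uM; a higher number here means a weaker effect of the compound at the concentration tested, a lower number a stronger effect:

compound 1, `Cc1c(C)c2c(c(C)c1OC(=O)CCC(=O)O)CCC(C)(COc1ccc(/C=C3\SC(=O)NC3=O)cc1)O2`: 115%
compound 2, `CC(C)=CCOc1c(C)c(C)c2c(c1C)CCC(C)(COc1ccc(/C=C3\SC(=O)NC3=O)cc1-c1ccc(F)cc1)O2`: 87%
compound 3, `CC(C)=CCOc1c(C)c(C)c2c(c1C)CCC(C)(COc1ccc(/C=C3\SC(=O)NC3=O)cc1F)O2`: 95%

Compound 1 stands highest of the three numbers in this assay. Its nearest neighbour is compound 3, whose number lies lower by more than the usual scatter; compound 2 is furthest, also lower by more than the scatter. Among the compounds with values here, the one step measured within a single structural change is a number 8 percentage points higher from compound 2 to compound 3 (within the scatter), and it lies within the scatter.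

The next compound, compound 4, `CC(C)=CCOc1c(C)c(C)c2c(c1C)CCC(C)(COc1ccc(/C=C3\SC(=O)NC3=O)cc1)O2`, differs from compound 1 in one place: 3-methylbut-2-en-1-yl in place of (2-carboxyethyl)carbonyl on an oxygen on an aromatic ring.

Within the data shown here, no measured pair differs only at this oxygen, so the step from compound 1 to compound 4 has no direct precedent. The step of a number 8 percentage points higher from compound 2 to compound 3 (within the scatter) concerns a different position and says nothing about it. Compounds 2 and 3 do carry the entering 3-methylbut-2-en-1-yl group and both sit below compound 1, but each also carries a further change on the other aromatic ring, so their gap to compound 1 cannot be assigned to the oxygen alone.

Compound 4 is therefore expected to give about 100% in this assay, within a range of 85% to 115%. That expectation means a step of a number 15 percentage points lower from compound 1 to compound 4 (beyond the scatter), a modest drop that may or may not clear the scatter.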

Compound 4, a percentage reported as activity, at one concentration (the size of the read-out at that concentration, not a potency): 76%
Beside the measured number, compound 4's estimate is 24 percentage points above it, and the stated range ends above it.
By their numbers in this assay, from the lowest: compound 4; then compounds 2 and 3 (each within the scatter of the next); then compound 1.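

In this assay the oxygen on an aromatic ring now has a direct reading: with the rest of the structure unchanged, 3-methylbut-2-en-1-yl in place of (2-carboxyethyl)carbonyl gives a number 39 percentage points lower from compound 1 to compound 4 (beyond the scatter) and so marks this oxygen as a place where the number responds to the group carried. With 3-methylbut-2-en-1-yl on that oxygen, compound 4 also anchors the aromatic carbon carrying the other change, since hydrogen in place of fluoro gives a number 19 percentage points lower from compound 3 to compound 4 (beyond the scatter) and hydrogen in place of 4-fluorophenyl gives a number 11 percentage points lower from compound 2 to compound 4 (beyond the scatter), which puts both substituted compounds on the weaker side of the hydrogen compound. Nothing available accounts for any of these steps, so they stand as observations only.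

Going by these compounds, it remains open whether the stronger effect of compound 4 depends on the unsaturated chain itself or only on the absence of the (2-carboxyethyl)carbonyl group, a question that a free hydroxyl or a saturated 3-methylbutyl ether on this oxygen would address. Also open, on these data alone, is whether the step at this oxygen keeps its size when fluoro or 4-fluorophenyl sits on the aromatic carbon.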